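The source may report more compounds than this note shows. Statements on the series, on what has been measured and on what is new or still open speak of the compounds shown alone.

Of the compounds shown here, three built on one shared core have been measured in a functional assay on A549 cells (Homo sapiens) for antiproliferative activity, read by MTT assay, with a stated time of 72 h; a higher number here means a weaker inhibitor, a lower number a stronger inhibitor. Compound 1 `COc1ccc(-c2ccc3ncn(-c4cc(OC)c(OC)c(OC)c4)c3c2)cc1O` gives 200 nM, compound 2 `COc1ccc(-c2ccc3ncn(-c4cc(OC)c(OC)c(OC)c4)c3c2)cc1F` gives 1430 nM, and compound 3 `COc1cc(-n2cnc3ccc(-c4ccccc4)cc32)cc(OC)c1OC` gives 3060 nM. Compound 3, which carries a plain phenyl, thus has the highest number of the three and is the weakest inhibitor among them. Compound 4 `COc1cc(-n2cnc3ccc(-c4cccc(C)c4C)cc32)cc(OC)c1OC` alters exactly that group, with 2,3-dimethylphenyl in place of phenyl on an aromatic carbon.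

Among the compounds with values here, two measured steps bear on this change, both read here in reverse, since each ends at the plain phenyl. The first is a 2.1-fold higher number from compound 2 to compound 3 (0.33 log units; beyond the scatter), and the second, much larger, is a 15-fold higher number from compound 1 to compound 3 (1.18 log units; beyond the scatter). Both show the plain phenyl giving a higher number than a substituted aryl group. However, the size of that gap depends strongly on the substituent, as a 7.2-fold higher number from compound 1 to compound 2 (0.85 log units; beyond the scatter) shows, and no compound yet measured carries a methyl on this ring. Only a modest gain in this assay is therefore expected, closer to the smaller step than to the larger one. The expected change is a 1.5-fold lower number from compound 3 to compound 4 (0.18 log units; within the scatter), which is a tentative estimate. For compound 4 the estimated value is 2000 nM, with an expected range from 600 nM to 6500 nM.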

Compound 4, half-maximal inhibitory concentration: 9250 nM
Estimate against measurement, compound 4: 4.6-fold (0.67 log units) below; the measured number lies above the stated range.
By their numbers in this assay, from the lowest: compound 1; then compound 2; then compound 3; then compound 4.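

In this assay, the plain phenyl of compound 3 had stood at the weak end of the series, but it proves not to be the upper limit for this position, as 2,3-dimethylphenyl gives a 3.0-fold higher number from compound 3 to compound 4 (0.48 log units; beyond the scatter). Substitution on this aromatic ring therefore has no single direction: 3-hydroxy-4-methoxyphenyl and 3-fluoro-4-methoxyphenyl give lower numbers than phenyl, compound 4 goes against that pattern, and the distance from the substituted compounds grows to a 6.5-fold higher number from compound 2 to compound 4 (0.81 log units; beyond the scatter) and to a 46-fold higher number from compound 1 to compound 4 (1.67 log units; beyond the scatter). No measurement at hand accounts for this rise, so the result records what the change does but gives no reason for it.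

The compounds shown leave open whether one methyl alone would raise the number as the 2,3-dimethylphenyl pair does, as both methyl groups enter together in compound 4. Going by these compounds, it also remains open whether an amine or a carboxylic acid on this ring would give a number nearer that of compound 1 or that of compound 4.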